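From 2-chloroethoxy to 3-chloropropoxy: a toxicity estimate

A few compounds are considered here, and "the series" means these few. Any claim that something is new, unique, unknown or untested is made for them only; others in the source may bear on it.

Measured in a toxicity assay on Huh-7.5 cells (Homo sapiens) for inhibition, read by MTT assay, with a stated time of 96 h; a higher number here means that more compound is tolerated, a lower number that less compound is tolerated:
Compound 1 `CN1CCN(Cc2ccc(NC(=O)c3ccc(OCCCCl)c(S(N)(=O)=O)c3)cc2C(F)(F)F)CC1`: 5470 nM
Compound 2 `CN1CCN(Cc2ccc(NC(=O)c3ccc(OCCCl)c([N+](=O)[O-])c3)cc2C(F)(F)F)CC1`: 9040 nM

Compound 2, at 9040 nM, stands within the scatter of compound 1, at 5470 nM. Compound 3 `CN1CCN(Cc2ccc(NC(=O)c3ccc(OCCCCl)c([N+](=O)[O-])c3)cc2C(F)(F)F)CC1` carries chloromethyl in place of chloro on a saturated chain carbon, two bonds along the chain from an oxygen on an aromatic ring. Among the measured compounds shown here, no measured pair shows this change alone, so no shift beyond the scatter is expected in this assay. The estimated 1.3-fold lower number from compound 2 to compound 3 (0.11 log units; within the scatter) is small and slightly downward. Compound 1 also bears 3-chloropropoxy, though its core differs, and gives 5470 nM. For compound 3 the estimate is 7000 nM, with an expected range of 3500 nM to 14000 nM.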

Compound 3, half-maximal cytotoxic concentration: 6800 nM
The estimate for compound 3 lay 1.0-fold (0.01 log units) above the measured number; the range from low to high includes it.
By their numbers in this assay, from the lowest: compounds 1, 3 and 2 (each within the scatter of the next).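

In this assay, 3-chloropropoxy in place of 2-chloroethoxy on the shared core leaves the tolerated concentration within the scatter (a 1.3-fold lower number from compound 2 to compound 3 (0.12 log units; within the scatter)). Compound 3 also makes a one-place comparison with compound 1 possible: nitro in place of sulfamoyl on an aromatic carbon likewise stays within the scatter (a 1.2-fold higher number from compound 1 to compound 3 (0.09 log units; within the scatter)). Nothing measured here explains either result.

Still open, going by these compounds, is whether a longer chain, or an amine or a carboxylic acid in place of chloro, would move the number beyond the scatter.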